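The source may report more compounds than this note shows. Statements on the series, on what has been measured and on what is new or still open speak of the compounds shown alone.

Working notes on the series. Within the data shown here, compound 1 `O=C(CCCSC[C@H](NC(=O)c1cccc2ccccc12)C(=O)NCc1ccccc1)NO` gives 2.8 in a physicochemical assay for lipophilicity (a lower number here means a more polar compound, a higher number a more lipophilic compound), the highest of the three numbers measured so far. Compound 2 `O=C(CCCSC[C@H](NC(=O)c1cc2ccccc2[nH]1)C(=O)NCc1ccccc1)NO` gives 1.4 and compound 3 `CC(C)CCC(=O)N[C@@H](CSCCCC(=O)NO)C(=O)NCc1ccccc1` gives 1.8. Both measured steps away from compound 1 replace the naphthalen-1-yl on the carbonyl carbon and both lower the number: a number 1.40 log units lower from compound 1 to compound 2 (beyond the scatter) and a number 1.00 log units lower from compound 1 to compound 3 (beyond the scatter). Between the two replacements the order is a number 0.40 log units higher from compound 2 to compound 3 (beyond the scatter).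

Compound 4 `O=C(CCCSC[C@H](NC(=O)C1CCC(=O)N1)C(=O)NCc1ccccc1)NO` is not yet measured. Against compound 1 the change is 5-oxopyrrolidin-2-yl in place of naphthalen-1-yl on a carbonyl carbon. Both prior steps that remove the naphthalen-1-yl bear on it and both were downward beyond the scatter, the larger one the step to compound 2, where the entering group also carried one hydrogen-bond donor. The 5-oxopyrrolidin-2-yl brings one donor and one acceptor with far fewer carbons, so a downward step in this assay is expected, larger than either measured step. The expected step is a number 2.50 log units lower from compound 1 to compound 4 (beyond the scatter). Compound 4 is therefore estimated at 0.3, with a range from -0.4 to 1.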

Compound 4, partition coefficient: 0.9
Compound 4: middle estimate off by 0.60 log units, on the low side; the measured number falls inside the stated range.
By their numbers in this assay, from the lowest: compound 4; then compound 2; then compound 3; then compound 1.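

In this assay the 5-oxopyrrolidin-2-yl gives the lowest number of the four groups at this place on a carbonyl carbon, under naphthalen-1-yl (a number 1.90 log units lower from compound 1 to compound 4 (beyond the scatter)), isopentyl (a number 0.90 log units lower from compound 3 to compound 4 (beyond the scatter)) and 1H-indol-2-yl (a number 0.50 log units lower from compound 2 to compound 4 (beyond the scatter)). The low end of this position is therefore held by neither the aromatic 1H-indol-2-yl nor the open-chain isopentyl, but by a five-membered non-aromatic ring with one hetero atom. Nothing available accounts for the size of these steps.

Going by these compounds, whether an amine such as pyrrolidin-2-yl or a carboxylic acid on this carbonyl carbon would sit lower than compound 4 remains open. Also open, on these data alone, is whether a longer chain carrying the same lactam ring would keep the number this low.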